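The source may report more compounds than this note shows. Statements on the series, on what has been measured and on what is new or still open speak of the compounds shown alone.

Among the measured compounds shown here, compound 2 `O=C(Nc1ccccc1Cl)C(Cl)Cl` stands lowest of the two numbers measured so far in a functional assay on A549 cells (Homo sapiens) for antiproliferative activity, read by MTT assay, with a stated time of 72 h; a higher number here means a weaker inhibitor, a lower number a stronger inhibitor: compound 2 gives 50200 nM, while compound 1 `O=C(Nc1ccccc1)C(Cl)Cl` gives 130000 nM. For the measured compounds named here, the single measured step, a 2.6-fold lower number from compound 1 to compound 2 (0.41 log units; beyond the scatter), brought chloro in place of hydrogen on an aromatic carbon. Compound 3 `O=C(Nc1ccccc1Br)C(Cl)Cl` differs from compound 2 by bromo in place of chloro on an aromatic carbon. Going by the values given here, only that one step bears on the change, and it concerned a different substituent; exchanging one halogen for another is expected to move the number little, so the step of a 1.3-fold lower number from compound 2 to compound 3 (0.10 log units; within the scatter) is expected to sit near the scatter. Compound 3 is therefore estimated at 40000 nM, between 18000 nM and 90000 nM.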

Compound 3, half-maximal inhibitory concentration: 37000 nM
The estimate for compound 3 lay 1.1-fold (0.03 log units) above the measured number, within the range that was stated.
By their numbers in this assay, from the lowest: compounds 3 and 2 (each within the scatter of the next); then compound 1.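

In this assay, the exchange of chloro for bromo on this aromatic carbon, ortho to a group of 6 heavy atoms, gives a 1.4-fold lower number from compound 2 to compound 3 (0.13 log units; within the scatter), so the two halogens cannot be told apart at this position. Bromo in place of hydrogen gives a 3.5-fold lower number from compound 1 to compound 3 (0.55 log units; beyond the scatter), which shows that a second halogen also gives a lower number than hydrogen here. Nothing shown gives a reason for either step. Going by these compounds, it remains open whether a methoxy group or an amine at this position would also give a lower number than hydrogen.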